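This account rests on a few compounds, and the source may have more. Where it says the series, first, only, none or still open, it means among the compounds named here.

Compound 3 (`CC(C)C(CC1NC(=O)NC1=O)c1ccc(-c2ccc3cccc(F)c3c2)[nH]c1=O`) gives 12300 nM in a physicochemical assay for solubility, in phosphate buffer, measured as kinetic solubility (a higher number here means a more soluble compound, a lower number a less soluble compound), within the scatter of compound 1 (`CC(C)C(/C=C1\NC(=O)NC1=O)c1ccc(-c2ccc3cccc(F)c3c2)[nH]c1=O`) at 10700 nM. Both lie under compound 2 (`CC(C)C(/C=C1\SC(=O)NC1=O)c1ccc(-c2ccc3cccc(F)c3c2)[nH]c1=O`) at 25600 nM. Compound 4 (`CC(C)C(c1ccc(-c2ccc3cccc(F)c3c2)[nH]c1=O)C1C(=O)NC(=O)N1C`) has the same atoms as compound 3, joined differently, with 3-methyl-2,5-dioxoimidazolidin-4-yl in place of (2,5-dioxoimidazolidin-4-yl)methyl on a saturated chain carbon bound to an aromatic carbon and a saturated chain carbon. The measured steps change the group at this same place, though none makes this change. They stay small: a 1.1-fold higher number from compound 1 to compound 3 (0.06 log units; within the scatter), a 2.4-fold higher number from compound 1 to compound 2 (0.38 log units; beyond the scatter) and a 2.1-fold lower number from compound 2 to compound 3 (0.32 log units; beyond the scatter). No clear direction can be drawn from them, so no shift beyond the scatter is expected in this assay, and the expected step is a 1.1-fold higher number from compound 3 to compound 4 (0.06 log units; within the scatter). The estimate for compound 4 is 14000 nM, with an expected range of 6000 nM to 32000 nM.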

Compound 4, solubility: 17900 nM
The estimate for compound 4 lay 1.3-fold (0.11 log units) below the measured number; the measured number falls inside the stated range.
By their numbers in this assay, from the lowest: compounds 1, 3, 4 and 2 (each within the scatter of the next, the first and the last beyond it).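

Relocating the ring as 3-methyl-2,5-dioxoimidazolidin-4-yl in place of (2,5-dioxoimidazolidin-4-yl)methyl leaves this assay within the scatter (a 1.5-fold higher number from compound 3 to compound 4 (0.16 log units; within the scatter)), even though the hydrogen-bond donor count falls. Compound 4 also lies within the scatter of the two compounds that differ beyond it from each other (a 1.4-fold lower number from compound 2 to compound 4 (0.16 log units; within the scatter); a 1.7-fold higher number from compound 1 to compound 4 (0.22 log units; within the scatter)). No supporting measurement bears on why this change is so small.

Compounds 3 and 4 do not separate the ring methyl from the shorter link to the ring. As far as these compounds go, whether an amine, a carboxylic acid or a longer chain at this place would shift this assay remains open.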